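The compounds below may be only part of what the source reports. "The series", "measured", "known", "first", "only" and "open" are said of these compounds alone.

Working notes on the series. In a functional assay on L1210 cells (Mus musculus) for inhibition (a higher number here means a weaker inhibitor, a lower number a stronger inhibitor), compound 1 (`C#CCN(Cc1ccc2nc(NCC(=O)O)nc(O)c2c1)c1ccc(C(=O)NC(CCC(=O)O)C(=O)O)cc1`) reads > 100000 nM, which is a limit of the assay and not a number. The standing of the measured set is short to state: the limit of > 100000 nM in this assay, at which 1 of the 2 values shown sits. Compound 2 (`COc1nc(O)c2cc(CN(C)c3ccc(C(=O)NC(CCC(=O)O)C(=O)O)cc3)ccc2n1`) gives a true number in this assay, at 7000 nM.

The next entry is compound 3 (`C#CCN(Cc1ccc2nc(S)nc(O)c2c1)c1ccc(C(=O)NC(CCC(=O)O)C(=O)O)cc1`), which has sulfanyl in place of (carboxymethyl)amino on an aromatic carbon of the core of compound 1, between two ring nitrogen atoms: sulfanyl in place of (carboxymethyl)amino on an aromatic carbon. Among the compounds with values here, no measured step isolates this change, and compound 1 offers only a limit as a starting point, so any size assigned to the move remains indirect.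

A shift toward stronger inhibition in this assay, beyond the scatter, is expected. Within the data shown here, that expectation rests on compound 2 at 7000 nM, the only numerical reading, and it remains a weak anchor. The expected move is an at least 10-fold lower number from compound 1 to compound 3 (1.00 log units; beyond the scatter). For compound 3 the estimated value is 10000 nM, with an expected range of 1500 nM to 70000 nM.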

Compound 3, half-maximal inhibitory concentration: 60000 nM
Beside the measured number, compound 3's estimate is 6.0-fold (0.78 log units) below it, and the stated range covers the measured number.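

In this assay compound 1 stands at > 100000 nM, which is a limit of the assay and not a number. With sulfanyl in place of (carboxymethyl)amino on this aromatic carbon, between two ring nitrogen atoms, compound 3 gives a true number at 60000 nM, so this position now has a reading that can be used as a reference for further changes with the rest of compound 1 held fixed. The change amounts to an at least 1.6-fold lower number from compound 1 to compound 3 (0.22 log units; that floor lies within the scatter), and it can be stated only as a floor because one end of the comparison is a limit: the limit of > 100000 nM in this assay, at which 1 of the 3 values shown sits.

Sulfanyl and (carboxymethyl)amino are the only two groups shown at this carbon on the otherwise unchanged structure of compound 1, so the reading of a plain amine, a methyl group or a longer chain carrying a carboxylic acid at the same place remains open. Within the data shown here, the true size of the step also remains open, and with only this pair the series gives no trend for this position.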